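The source may hold more compounds than are shown below. What is called first, only, known or untested is meant among the compounds shown, and "the series" means these compounds.

Measured so far in a functional assay on SF-539 cells (Homo sapiens) for inhibition, read by sulforhodamine B assay, with a stated time of 48 h; a lower number here means a stronger inhibitor of growth, a higher number a weaker inhibitor of growth:
Compound 1 `COc1ccc(-c2cc(/C=C/C(=O)c3ccc(N)cc3)[nH]n2)cc1`: 3480 nM
Compound 2 `COc1cc(-c2cc(/C=C/C(=O)c3ccc(N)cc3)[nH]n2)cc(OC)c1OC`: 2660 nM

Compound 2 has the lower of the two numbers, but its gap to compound 1 lies within the scatter, so the two cannot be ranked against each other. Compound 3 `COc1cc(-c2cc(/C=C/C(=O)c3ccc(Cl)c(Cl)c3)[nH]n2)cc(OC)c1OC` is the next compound to be tested. It differs from compound 2 in one place: 3,4-dichlorophenyl in place of 4-aminophenyl on a carbonyl carbon. Among the compounds with values here, no measured pair shows what this kind of exchange does here, so the step is an open question. The expectation is a step no larger than the scatter, with the direction uncertain, giving a 1.2-fold lower number from compound 2 to compound 3 (0.08 log units; within the scatter). Compound 3 is therefore expected to fall near 2200 nM, between 700 nM and 7000 nM.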

Compound 3, concentration for total growth inhibition: 18700 nM
The estimate for compound 3 lay 8.5-fold (0.93 log units) below the measured number; measured number above the stated range.
By their numbers in this assay, from the lowest: compounds 2 and 1 (each within the scatter of the next); then compound 3.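

Within the data shown here, compounds 1 and 2 both carry 4-aminophenyl on the carbonyl carbon, so compound 3 gives the first view of a change at this place. In this assay, 3,4-dichlorophenyl in place of 4-aminophenyl gives a 7.0-fold higher number from compound 2 to compound 3 (0.85 log units; beyond the scatter), which means weaker growth inhibition. Nothing available here explains this step.

On these data alone, the exchange removes the amine and adds both chlorines in one step, so the contribution of each stays open. Plain phenyl or 4-chlorophenyl at this place would help separate them.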